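Trading a Z Double Bond for E in Compound 1

The source may hold more compounds than are shown below. What is called first, only, known or untested is meant among the compounds shown, and "the series" means these compounds.

Compound 1 `CCCCC/C=C\C[C@@]1(O)C=C(Cl)C(=O)/C1=C\C=C\CCCC(=O)OC`: 800 nM
Compound 2 `CCCCC/C=C\C[C@]1(O)C=CC(=O)/C1=C/C=C/CCCC(=O)OC`: 5400 nM

In a functional assay on PC-3 cells (Homo sapiens) for cytotoxicity, read by sulforhodamine B assay, with a stated time of 72 h (a higher number here means a weaker inhibitor, a lower number a stronger inhibitor), compound 1 gives 800 nM, the lowest of the two numbers, while compound 2 gives 5400 nM, a higher number beyond the scatter. Compound 3 `CCCCC/C=C\C[C@@]1(O)C=C(Cl)C(=O)/C1=C/C=C/CCCC(=O)OC` has not been measured. It is compound 1 redrawn: the two compounds have the same atoms and bonds and differ only in configuration as drawn: 1 of 4 stereo elements differ; a double bond is drawn Z in compound 1 and E in compound 3. Within the data shown here, no measured pair isolates this change, so the size of its step is unknown. In this assay the step of a 2.5-fold higher number from compound 1 to compound 3 (0.40 log units; beyond the scatter) is expected to lie beyond the scatter, toward weaker inhibition. Compound 3 is therefore estimated at 2000 nM, within 600 nM to 6500 nM.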

Compound 3, half-maximal inhibitory concentration: 1900 nM
Estimate against measurement, compound 3: 1.1-fold (0.02 log units) above, and the stated range covers the measured number.
By their numbers in this assay, from the lowest: compound 1; then compound 3; then compound 2.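

In this assay, the double bond drawn Z in compound 1 and E in compound 3 proves to matter on its own: the step is a 2.4-fold higher number from compound 1 to compound 3 (0.38 log units; beyond the scatter) and points toward weaker inhibition. The earlier compounds shown here could not separate this change from their other differences. The step belongs to this single change of configuration, because nothing else separates the two: the fact that compounds 1 and 3 differ only in the configuration as drawn.

On these data alone, whether the E form would cost as much with a bromine in place of the chlorine stays open. So does the effect of this change with a carboxylic acid in place of the methyl ester.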